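Stripping the Aryl Group from a Triazole Lactone

The source may hold more compounds than are shown below. What is called first, only, known or untested is meant among the compounds shown, and "the series" means these compounds.

Among the measured compounds shown here, compound 2 `O=C1O[C@H]([C@@H](O)Cn2cc(-c3ccc(Br)cc3)nn2)C(OCc2ccccc2)=C1OCc1ccccc1` gives 5070 nM in a functional assay on HepG2 cells (Homo sapiens) for antiproliferative activity, read by MTT assay, with a stated time of 72 h (a lower number here means a stronger inhibitor, a higher number a weaker inhibitor), the lowest of the two numbers measured so far. Compound 1 `COc1ccc(-c2cn(C[C@H](O)[C@H]3OC(=O)C(OCc4ccccc4)=C3OCc3ccccc3)nn2)cc1` carries a methoxy group where compound 2 carries a bromine; in this assay compound 1 gives 46400 nM, and the step of a 9.2-fold lower number from compound 1 to compound 2 (0.96 log units; beyond the scatter) is the only measured one. Compound 3 `O=C1O[C@H]([C@@H](O)Cn2ccnn2)C(OCc2ccccc2)=C1OCc1ccccc1` has not yet been measured. It differs from compound 2 in this way: hydrogen in place of 4-bromophenyl on an aromatic carbon. No measured step removes the whole group; the one shown only swaps its substituent, and that swap alone moved the number beyond the scatter, so removing the group at the same position is unlikely to leave the number unchanged. Because compound 1 already gives 46400 nM with only the substituent altered, compound 3 is expected to show a 7.9-fold higher number from compound 2 to compound 3 (0.90 log units; beyond the scatter), toward a higher number. Compound 3 is estimated at 40000 nM, within 10000 nM to 150000 nM.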

Compound 3, half-maximal inhibitory concentration: > 100000 nM
Compound 3: no number, only a limit; the forecaster's own chance of this, stated with the estimate: 25%; at least 2.5-fold (0.39 log units) between middle value and limit.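

Compound 3 gives no number, only a limit: the limit of > 100000 nM in this assay, at which 1 of the 3 values shown sits. Replacing the 4-bromophenyl with hydrogen gives an at least 19-fold higher number from compound 2 to compound 3 (1.29 log units; beyond the scatter), and replacing the 4-methoxyphenyl with hydrogen gives an at least 2.1-fold higher number from compound 1 to compound 3 (0.33 log units; beyond the scatter). The earlier step showed only that the substituent on this aryl ring changes the result, whereas these steps show that losing the entire ring from the aromatic carbon of the triazole takes the compound to the assay's limit, while both compounds that keep a ring give a number.

The limit leaves the full size of both steps unknown. The compounds shown also leave open how much of the aryl group is needed, such as whether an unsubstituted phenyl ring, or a methyl group in place of the ring, would still give a measurable number.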